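This account rests on a few compounds, and the source may have more. Where it says the series, first, only, none or still open, it means among the compounds named here.

Compound 1 `O=C(NNc1cccc(Cl)c1)c1ccc(NS(=O)(=O)c2cnc(O)nc2O)cc1`: 17400 nM
Compound 2 `Cc1ccccc1NNC(=O)c1cccc(NS(=O)(=O)c2cnc(O)nc2O)c1`: > 20000 nM (a limit)

Both compounds were tested in a functional assay on MDA-MB-231 cells (Homo sapiens) for antiproliferative activity, read by MTT assay, with a stated time of 24 h; a lower number here means a stronger inhibitor, a higher number a weaker inhibitor. Compound 2 gives > 20000 nM, and this value is a limit of the assay, not a number. Among the measured compounds shown here, compound 1, at 17400 nM, gives the only actual number available here.

Compound 3 `O=C(NNc1ccccc1Cl)c1cccc(NS(=O)(=O)c2cnc(O)nc2O)c1` differs from compound 2 by one swap chloro in place of methyl on an aromatic carbon, ortho to a large group. For the measured compounds named here, no measured pair yet shows what a single change does in this assay. A shift beyond the scatter is therefore not expected, in either direction, and compound 3 may also end up reported only as a limit. The expected step is an at least 1.0-fold lower number from compound 2 to compound 3 (0.02 log units; that floor lies within the scatter). Compound 3 is estimated at 19000 nM, with an expected range of 9000 nM to 40000 nM.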

Compound 3, half-maximal inhibitory concentration: 2090 nM
Compound 3: middle estimate off by 9.1-fold (0.96 log units), on the high side; measured number outside the range, below it.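

In this assay, among the compounds shown here, this is the first single change that can be read: chloro in place of methyl on an aromatic carbon, ortho to a large group, gives an at least 9.5-fold lower number from compound 2 to compound 3 (0.98 log units; beyond the scatter). This place on the ring is therefore not indifferent, since exchanging one heavy atom for another, with no hydrogen-bond donor or acceptor entering or leaving, moves the number beyond the scatter. The step can only be stated as a minimum because compound 2 is reported as a limit and not as a number: the limit of > 20000 nM in this assay, at which 1 of the 3 values shown sits.

The compounds shown leave open whether the lower number is particular to chloro or would also come with fluoro, methoxy or an amine at this place. They also leave open whether the same swap would lower the number on any other core.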